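This account rests on a few compounds, and the source may have more. Where it says the series, first, only, none or still open, it means among the compounds named here.

Measured in a functional assay on Caco-2 cells (Homo sapiens) for cytotoxicity, read by MTT assay, with a stated time of 24 h; on this read-out lower numbers stand for stronger inhibition and higher numbers for weaker inhibition:
compound 1 `COc1ccc(/C=C2\SC(Nc3ccc(S(N)(=O)=O)cc3)=NC2=O)cc1`, 1330 nM
compound 2 `NS(=O)(=O)c1ccc(Nc2nc3nc(=O)[nH]c(-c4ccccc4)c3s2)cc1`, 334 nM
compound 3 `NS(=O)(=O)c1ccc(Nc2nc3nc(=S)[nH]c(-c4ccccc4)c3s2)cc1`, 333 nM

Compound 3 gives the lowest number of the three, yet compound 2 gives a number within the scatter of it, so the two cannot be told apart. Compound 1, with the open-chain core, gives a number beyond the scatter and higher than compound 3.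

Compound 4 `NS(=O)(=O)c1ccc(Nc2nc3nc(=S)[nH]c(-c4ccc(Cl)cc4)c3s2)cc1` differs from compound 3 by chloro in place of hydrogen on an aromatic carbon. Among the compounds with values here, no measured pair with this difference exists, so the size of the step is unknown; in this assay a small step, within the scatter, is expected, direction uncertain.

The expected step of a 1.2-fold lower number from compound 3 to compound 4 (0.08 log units; within the scatter) is therefore estimated as small. Compound 4 is expected to give 280 nM, range 100 nM to 800 nM.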

Compound 4, half-maximal inhibitory concentration: 333 nM
For compound 4 the middle estimate is 1.2-fold (0.08 log units) below the measured one; the measured number falls inside the stated range.
By their numbers in this assay, from the lowest: compounds 3, 4 and 2 (each within the scatter of the next); then compound 1.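

In this assay, within the data shown here, the change from phenyl to 4-chlorophenyl gives no change at the digits printed from compound 3 to compound 4 (within the scatter) and is the first step that can be read at this position. The aromatic carbon para to a large group therefore accepts chloro without a shift beyond the scatter, although a single step sets no trend. No available evidence bears on this result.

From the compounds shown here alone, whether an amine or a carboxylic acid at the same carbon would shift the number remains open. So does whether chloro would give the same outcome on the core of compound 2.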